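A few compounds are considered here, and "the series" means these few. Any claim that something is new, unique, unknown or untested is made for them only; others in the source may bear on it.

Compound 1 `Nc1nn(C(=O)Nc2ccc(Cc3ccccc3)cc2)c2ccccc12` and compound 2 `Nc1nn(C(=O)Nc2ccc(Cc3ccccc3)cc2)c2ccc(Cl)cc12` share the same core and differ only at one carbon of the fused two-ring part. In a functional assay on SW-620 cells (Homo sapiens) for antiproliferative activity, read by sulforhodamine B assay, with a stated time of 48 h (on this read-out lower numbers stand for stronger inhibition of growth and higher numbers for weaker inhibition of growth), compound 1 gives 3620 nM, while compound 2 gives 56.5 nM. Within the data shown here, the single recorded step, a 64-fold lower number from compound 1 to compound 2 (1.81 log units; beyond the scatter), is the only guide available here. Among the measured compounds shown here, on these two numbers compound 2 stands lowest, with compound 1 the only neighbour.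

Compound 3 `Nc1ccc2c(c1)c(N)nn2C(=O)Nc1ccc(Cc2ccccc2)cc1` takes the next step: amino in place of chloro on an aromatic carbon. For the measured compounds named here, the one measured step that bears on this place, a 64-fold lower number from compound 1 to compound 2 (1.81 log units; beyond the scatter), shows that what sits on this carbon matters a great deal, but it says nothing directly about amino, which brings a hydrogen-bond donor and acceptor where chloro brought none. Since the gain in compound 2 rests on chloro, and compound 1 shows the bare carbon at 3620 nM, a partial return toward the weaker end is expected, so the step of an 8.8-fold higher number from compound 2 to compound 3 (0.95 log units; beyond the scatter) is estimated upward with wide uncertainty. For compound 3 the estimate in this assay is 500 nM, within a range from 100 nM to 3000 nM.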

Compound 3, concentration for 50% growth inhibition: 4480 nM
For compound 3 the middle estimate is 9.0-fold (0.95 log units) below the measured one; the measured number lies above the stated range.
By their numbers in this assay, from the lowest: compound 2; then compounds 1 and 3 (each within the scatter of the next).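

In this assay the step of a 79-fold higher number from compound 2 to compound 3 (1.90 log units; beyond the scatter) takes away the gain that chloro brought, so this carbon does not reward just any group put in place of hydrogen. The step of a 1.2-fold higher number from compound 1 to compound 3 (0.09 log units; within the scatter) lies within the scatter, which means that amino on this carbon cannot be told apart from the plain hydrogen of compound 1, and among these three compounds only chloro stands out. Nothing measured here explains why chloro and amino, each a single heavy atom on the same aromatic carbon, give such different results.

From the compounds shown here alone, it remains open whether the gain belongs to chloro alone or would also appear with fluoro, bromo, methyl or methoxy on this carbon, since one strong group and one group matching hydrogen do not yet make a trend. Going by these compounds, it is also open whether the same wide gap between chloro and amino would hold in other cell lines, as all three numbers come from a single cell type.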